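A Halogen Swap on the Fused Aromatic Core

A few compounds are considered here, and "the series" means these few. Any claim that something is new, unique, unknown or untested is made for them only; others in the source may bear on it.

Within the data shown here, compound 1 `Clc1cccc2c1CC2CN1CCN(c2cccc3c2OCCO3)CC1` is the one member of this small set that gives an actual number in a functional assay on the whole organism for agonist activity, with Rattus norvegicus as the target; a higher number here means that more compound is needed for the effect, a lower number that less compound is needed: compound 1 needs 40 mg/kg to produce the effect. Compound 2 `Clc1cccc2c1CC2CCCN1CCN(c2cccc3c2OCCO3)CC1` does not give a number in this assay but only a limit, and for compound 2 that limit is > 10 mg/kg. So where compound 1 stands is simply stated: it holds the only real value, the other entry being (the limit of > 10 mg/kg in this assay, at which 1 of the 2 values shown sits). Among the measured compounds shown here, no step between two measured compounds is available here, so nothing measured tells how a single change on the core shifts the dose.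

Compound 3 `Fc1cccc2c1CC2CN1CCN(c2cccc3c2OCCO3)CC1` is the unmeasured relative of compound 1; the whole difference is fluoro in place of chloro on an aromatic carbon. For the measured compounds named here, with no measured step to lean on, the expected change in this assay is none beyond the usual scatter, in either direction. The step expected is a 1.3-fold higher number from compound 1 to compound 3 (0.10 log units; within the scatter), a shift that stays inside that scatter. Compound 3 is therefore estimated at 50 mg/kg, with an expected range from 15 mg/kg to 150 mg/kg.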

Compound 3, minimum effective dose: > 10 mg/kg
Compound 3: no number, only a limit; the forecaster's own chance of this, stated with the estimate: 30%; the middle value lies beyond the limit too.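

Among these compounds, compound 3 gives > 10 mg/kg in this assay as a limit and not a number, so no step from compound 1 to compound 3 can be read. The compounds shown leave open whether fluoro in place of chloro on an aromatic carbon changes the dose needed at all, and in which direction, with most entries resting on a limit: the limit of > 10 mg/kg in this assay, at which 2 of the 3 values shown sit.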